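Pyridin-2-yl for phenyl on the benzylamino arm

The source may report more compounds than this note shows. Statements on the series, on what has been measured and on what is new or still open speak of the compounds shown alone.

compound 1 `Cc1nc(NCCCC(F)(F)F)nc(N[C@@H]2C[C@H](CO)[C@@H](O)[C@H]2O)c1-c1nc2ccccc2s1` gives 3000 nM
compound 2 `Cc1nc(Nc2ccccc2)nc(N[C@@H]2C[C@H](CO)[C@@H](O)[C@H]2O)c1-c1nc2ccccc2s1` gives > 25000 nM
compound 3 `Cc1nc(NCc2ccccc2)nc(N[C@@H]2C[C@H](CO)[C@@H](O)[C@H]2O)c1-c1nc2ccccc2s1` gives 9000 nM

These three compounds share one core and differ only in the group on the outer amino nitrogen. In an ADME assay on cells (Homo sapiens) for cytotoxicity, read by polymerase chain reaction, with a stated time of 3 days (a higher number here means that more compound is tolerated, a lower number that less compound is tolerated), compound 3 has the highest of the two numbers; its nearest neighbour is compound 1, with a 3.0-fold higher number from compound 1 to compound 3 (0.48 log units; beyond the scatter). For compound 2 this assay reports only a limit, (the limit of > 25000 nM in this assay, at which 1 of the 3 values shown sits), and not a number. The step of an at least 2.7-fold lower number from compound 2 to compound 3 (0.44 log units; beyond the scatter) therefore rests on a limit on one side.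

Compound 4 `Cc1nc(NCc2ccccn2)nc(N[C@@H]2C[C@H](CO)[C@@H](O)[C@H]2O)c1-c1nc2ccccc2s1` is not yet measured. Relative to compound 3 it carries pyridin-2-yl in place of phenyl on a saturated chain carbon bound to a nitrogen on an aromatic ring. Among the measured compounds shown here, none of the measured steps exchanges one six-membered aromatic ring for another; a 3.0-fold higher number from compound 1 to compound 3 (0.48 log units; beyond the scatter) and an at least 2.7-fold lower number from compound 2 to compound 3 (0.44 log units; beyond the scatter) concern the link between the aromatic nitrogen and the ring, not the ring itself. The change from compound 3 to compound 4 keeps that link and alters only the ring, so no step beyond the scatter is expected, no change at the digits printed from compound 3 to compound 4 (within the scatter). Compound 4 is estimated to give 9000 nM, between 3500 nM and 25000 nM, with some chance that this assay again returns only a limit.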

Compound 4, half-maximal cytotoxic concentration: 13000 nM
Compound 4: middle estimate off by 1.4-fold (0.16 log units), on the low side; the measured number falls inside the stated range.
By their numbers in this assay, from the lowest: compound 1; then compounds 3 and 4 (each within the scatter of the next). At a limit, above all of these: compound 2.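

Among the compounds shown here, exchanging one six-membered aromatic ring for another on a saturated chain carbon bound to a nitrogen on an aromatic ring gives a 1.4-fold higher number from compound 3 to compound 4 (0.16 log units; within the scatter) in this assay, so at this place, and for this one exchange, the added ring nitrogen and hydrogen-bond acceptor leave no step that can be told from the scatter. The step from the trifluorinated chain, already seen with the phenyl ring of compound 3, stands with the new ring as well and is a 4.3-fold higher number from compound 1 to compound 4 (0.64 log units; beyond the scatter). Compound 2 remains at a limit rather than a number, and an at least 1.9-fold lower number from compound 2 to compound 4 (0.28 log units; that floor lies within the scatter) gives only a floor, so the directly attached phenyl cannot be set apart from the (pyridin-2-yl)methyl group on this evidence: the limit of > 25000 nM in this assay, at which 1 of the 4 values shown sits.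

Left open is whether pyridin-3-yl, pyridin-4-yl or a pyrimidine ring on the same carbon would behave as pyridin-2-yl does, and whether an amine or a carboxylic acid on that ring would shift the number in this assay. Nothing given here accounts for any cause of these numbers.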